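The compounds below may be only part of what the source reports. "The series", "measured", "known", "first", "only" and "open" are said of these compounds alone.

Within the data shown here, the two compounds measured so far share one core and differ only in the chain that hangs from the oxygen on the aromatic ring. Compound 1 `COc1ccc(-c2coc3cc(OCCCSC(=S)N4CCCC4)ccc3c2=O)cc1` is the weaker of the two in a functional assay on PC-3 cells (Homo sapiens) for inhibition, read by MTT assay, with a stated time of 48 h (on this read-out lower numbers stand for stronger inhibition and higher numbers for weaker inhibition), where compound 1 gives 19400 nM. Among the measured compounds shown here, compound 2 `COc1ccc(-c2coc3cc(OCCSC(=S)N4CCN(C(=O)OC(C)(C)C)CC4)ccc3c2=O)cc1` gives 3640 nM in this assay, a markedly lower number that lies beyond the usual scatter, so compound 1 stands as the higher of the two numbers known.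

Compound 3 `COc1ccc(-c2coc3cc(OCCCCBr)ccc3c2=O)cc1` has not yet been measured. It departs from compound 1 by one change: a group of 2 heavy atoms (1 carbon, 1 bromine; no ring) in place of a group of 8 heavy atoms (5 carbon, 1 nitrogen, 2 sulfur; one five-membered non-aromatic ring with 1 hetero atom), on a saturated chain carbon, three bonds along the chain from an oxygen on an aromatic ring. The larger group with its five-membered ring and two sulfur atoms is thus gone, and a bromomethyl stands three bonds along the chain from the oxygen on the aromatic ring.

For the measured compounds named here, no measured pair shows a step of this kind, so the expectation rests on compound 1 alone, whose value 19400 nM already sits at the weak end. Compound 3 is expected to stay near that level or to be somewhat weaker, an estimated step of a 1.5-fold higher number from compound 1 to compound 3 (0.19 log units; within the scatter) in this assay. The estimate for compound 3 in this assay is 30000 nM, with a range from 8000 nM to 120000 nM.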

Compound 3, half-maximal inhibitory concentration: 55600 nM
Beside the measured number, compound 3's estimate is 1.9-fold (0.27 log units) below it; measured number inside the range.
By their numbers in this assay, from the lowest: compound 2; then compound 1; then compound 3.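

Among these compounds, the exchange of the group of compound 1, with its five-membered ring and two sulfur atoms, for bromomethyl, on a saturated chain carbon, three bonds along the chain from an oxygen on an aromatic ring, gives a 2.9-fold higher number from compound 1 to compound 3 (0.46 log units; beyond the scatter) in this assay and is the first single change at this place that can be read. It shows that the number still responds to the group carried here, even though compound 1 already stood at the weak end, and that the departing group lies on the side of stronger inhibition relative to bromomethyl. The data offer no measurement that explains the step or tells whether the ring, the sulfur atoms or the double bond of the departing group accounts for it.

On these data alone, with only one replacement to read at this place, it remains open whether an amine or a carboxylic acid in place of bromomethyl would bring the number back towards that of compound 1 or take it lower still. As far as these compounds go, how a longer chain would act with either group also remains open.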